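The source may hold more compounds than are shown below. What is called first, only, known or untested is meant among the compounds shown, and "the series" means these compounds.

Compound 1 `CC[C@H]1c2cc(Cl)ccc2C(=O)N1c1cncc2c1CCC[C@H]2NC(C)=O` gives 3630 nM in an ADME assay on cells for inhibition of cytochrome P450 11B1, mitochondrial (Homo sapiens), read by HTRF; on this read-out higher numbers stand for weaker inhibition and lower numbers for stronger inhibition.
Compound 2 `CCC1c2cc(Cl)ccc2C(=O)N1c1cccnc1` gives 3340 nM in this assay.
Compound 3 `N#Cc1ccc2c(c1)CN(c1cccnc1)C2=O` gives 15500 nM in this assay.

Of these three numbers, compound 2 holds the lowest. Compound 1 sits so close to it that the two cannot be told apart within the usual scatter of the measurement, so neither can be called the stronger inhibitor. Compound 3 stands clearly apart, with a number beyond the scatter and on the side of weaker inhibition.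

Compound 4 `CC1c2cc(Cl)ccc2C(=O)N1c1cccnc1` has not yet been measured. It differs from compound 2 in a single spot: hydrogen in place of methyl on a saturated chain carbon bound to a saturated ring carbon. Seen one bond further out, the change reads ethyl to methyl.

Going by the values given here, no pair among the measured compounds shows this kind of change, so there is no measured step to lean on. With only one carbon removed from a short chain, and nothing in the measured set pointing either way, the step from compound 2 to compound 4 is expected to be small, most likely none beyond the scatter, as a 1.2-fold higher number from compound 2 to compound 4 (0.08 log units; within the scatter) expresses. On that basis compound 4 is estimated at 4000 nM in this assay, with a range from 1500 nM to 12000 nM.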

Compound 4, half-maximal inhibitory concentration: 1250 nM
Beside the measured number, compound 4's estimate is 3.2-fold (0.51 log units) above it; the measured number lies below the stated range.
By their numbers in this assay, from the lowest: compound 4; then compounds 2 and 1 (each within the scatter of the next); then compound 3.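

Going from ethyl to methyl on a saturated chain carbon bound to a saturated ring carbon is the first single-place change in this set, and in this assay it gives a 2.7-fold lower number from compound 2 to compound 4 (0.43 log units; beyond the scatter) as a modest step that lies beyond the scatter. The earlier compounds shown here differed in more than one place, so they could not show that this spot matters on its own; this pair shows that removing just one carbon from the chain there is enough to produce a real difference, with the shorter chain giving stronger inhibition. Nothing available explains why this single carbon changes the number, so the result stands as an observation about this one pair and offers no cause.

As far as these compounds go, a single pair gives one step and no trend, so it remains open whether the number would keep falling with a plain hydrogen on that ring carbon or rise again with a longer chain such as propyl. From the compounds shown here alone, it also remains open how a hydroxyl or an amine at the end of the chain would compare, and whether the same ethyl to methyl change would give a similar step on the core of compound 1.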